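Swapping a Carbamoyl for a Sulfonyl Group on Piperazine

The source may hold more compounds than are shown below. What is called first, only, known or untested is meant among the compounds shown, and "the series" means these compounds.

Measured so far:
compound 1, `CC(=O)N1CCN([C@H]2CC[C@H](Nc3ncnc4[nH]cc(C5CCOCC5)c34)CC2)CC1`: 1.3
compound 2, `CN(C)C(=O)N1CCN([C@H]2CC[C@H](Nc3ncnc4[nH]cc(C5CCOCC5)c34)CC2)CC1`: 1.5

Both compounds were measured in a physicochemical assay for lipophilicity, using the shake flask method, at pH 7.4; a higher number here means a more lipophilic compound, a lower number a more polar compound. Compound 1 gives 1.3 and compound 2 gives 1.5. Within the data shown here, compound 2 holds the higher of the two numbers, but the single measured step, a number 0.20 log units higher from compound 1 to compound 2 (within the scatter), lies within the scatter, so the two values cannot be told apart with confidence.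

Compound 3, `CS(=O)(=O)N1CCN([C@H]2CC[C@H](Nc3ncnc4[nH]cc(C5CCOCC5)c34)CC2)CC1`, has not yet been measured. It differs from compound 2 in one place: methylsulfonyl in place of dimethylcarbamoyl on an amine nitrogen in a ring. Among the measured compounds shown here, no measured step mirrors this exchange; the only step available, from compound 1 to compound 2, concerns a different group on the carbonyl carbon and was within the scatter, so it offers no direct guide. The expectation for compound 3 therefore rests on the structural change alone and carries a wide margin. A small downward step is estimated, a number 0.40 log units lower from compound 2 to compound 3 (beyond the scatter), which may or may not exceed the scatter. Compound 3 is expected to give about 1.1, within a range from 0.7 to 1.5.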

Compound 3, distribution coefficient: 1.5
Beside the measured number, compound 3's estimate is 0.40 log units below it; measured number inside the range.
By their numbers in this assay, from the lowest: compounds 1, 2 and 3 (each within the scatter of the next).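

In this assay the exchange of dimethylcarbamoyl for methylsulfonyl on this amine nitrogen in a ring gives no change at the digits printed from compound 2 to compound 3 (within the scatter) and so leaves no readable mark on the result. Set against the acetyl group of compound 1, methylsulfonyl gives a number 0.20 log units higher from compound 1 to compound 3 (within the scatter) and again stays too close to separate, so compounds 1, 2 and 3 cannot be told apart in this measurement. Among these compounds, the earlier pair showed only that the group on the carbonyl carbon could differ without a readable shift, whereas compound 3 extends this to a group with no carbonyl at all, a sulfonyl built around sulfur, on the same core and at the same nitrogen.

No supporting measurement is available to explain why these three groups read alike. On these data alone, it remains open whether this flat picture would hold for a quite different group on this nitrogen, such as a carboxylic acid, an amine or a longer chain on the sulfonyl.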